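Sulfonamide series: methyl replaces the fluorinated carbinol

The source may report more compounds than this note shows. Statements on the series, on what has been measured and on what is new or still open speak of the compounds shown alone.

Measured so far:
compound 1 `Cc1cc(C(O)(C(F)(F)F)C(F)(F)F)ccc1N(CC(C)C)S(=O)(=O)c1ccc2c(c1)C(O)CC(C1CCOCC1)O2` — 4.37
compound 2 `CCc1ccc(N(CC(C)C)S(=O)(=O)c2ccc(OCC3CCOCC3)c(CN)c2)cc1` — 3.25

In a physicochemical assay for lipophilicity, at pH 7.4 (a lower number here means a more polar compound, a higher number a more lipophilic compound), compound 1 gives 4.37, the higher of the two numbers. Compound 2 gives 3.25 in this assay, and the gap between the two lies beyond the scatter. Compound 3 `Cc1ccc(N(CC(C)C)S(=O)(=O)c2ccc3c(c2)C(O)CC(C2CCOCC2)O3)c(C)c1` differs from compound 1 in one place: methyl in place of 2,2,2-trifluoro-1-hydroxy-1-(trifluoromethyl)ethyl on an aromatic carbon. Within the data shown here, no measured pair shows this change, so the expectation rests on compound 1 alone. The step is expected to be downward and beyond the scatter, at a number 0.82 log units lower from compound 1 to compound 3 (beyond the scatter). For compound 3 the estimated value in this assay is 3.55, with a range from 3 to 4.1.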

Compound 3, distribution coefficient: 4.19
Compound 3: the middle estimate sits 0.64 log units below what was measured; measured number above the stated range.
By their numbers in this assay, from the lowest: compound 2; then compounds 3 and 1 (each within the scatter of the next).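

In this assay, methyl in place of 2,2,2-trifluoro-1-hydroxy-1-(trifluoromethyl)ethyl on this aromatic carbon gives a number 0.18 log units lower from compound 1 to compound 3 (within the scatter). At this position, then, a group of 10 heavy atoms and a methyl of 1 heavy atom cannot be told apart on this read-out, on the shared core of compound 1 and compound 3. No measurement shown here offers an explanation for this result.

From the compounds shown here alone, what a carboxylic acid at this position would give in this assay remains open. This single step also cannot show whether the same exchange would give a similar result on another core.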